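A few compounds are considered here, and "the series" means these few. Any claim that something is new, unique, unknown or untested is made for them only; others in the source may bear on it.

Compound 1 `O=S(=O)(Nc1ccc2cc[nH]c2c1)c1ccc(F)cc1`: 30900 nM
Compound 2 `O=S(=O)(Nc1ccc2cc[nH]c2c1)c1ccc(Br)cc1`: 37800 nM
Compound 3 `Cc1ccc(S(=O)(=O)Nc2ccc3cc[nH]c3c2)cc1`: 37200 nM

All three values come from a functional assay on MCF7 cells (Homo sapiens) for antiproliferative activity, read by MTT assay, with a stated time of 24 h; a higher number here means a weaker inhibitor, a lower number a stronger inhibitor. Compound 3 cannot be told apart from the other two, as its value lies within the scatter of both. Compound 4 `COc1ccc(S(=O)(=O)Nc2ccc3cc[nH]c3c2)cc1` has methoxy in place of methyl on an aromatic carbon, para to a large group: methoxy in place of methyl on an aromatic carbon. The measured swaps at this same carbon are the closest guide: a 1.2-fold higher number from compound 1 to compound 2 (0.09 log units; within the scatter), a 1.2-fold higher number from compound 1 to compound 3 (0.08 log units; within the scatter) and a 1.0-fold lower number from compound 2 to compound 3 (0.01 log units; within the scatter). None of them involves methoxy, but none moved the number noticeably, so no step beyond the scatter is expected in this assay. The estimated change is a 1.1-fold lower number from compound 3 to compound 4 (0.03 log units; within the scatter). Compound 4 is expected at about 35000 nM, within an estimated range of 18000 nM to 65000 nM.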

Compound 4, half-maximal inhibitory concentration: 57200 nM
The estimate for compound 4 lay 1.6-fold (0.21 log units) below the measured number, and the stated range covers the measured number.
By their numbers in this assay, from the lowest: compounds 1, 3, 2 and 4 (each within the scatter of the next).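

Methoxy adds an oxygen and a hydrogen-bond acceptor on this aromatic carbon, yet in this assay all three new steps stay within the scatter (a 1.5-fold higher number from compound 3 to compound 4 (0.19 log units; within the scatter)) and (a 1.5-fold higher number from compound 2 to compound 4 (0.18 log units; within the scatter)) and (a 1.9-fold higher number from compound 1 to compound 4 (0.27 log units; within the scatter)). Fluoro, bromo, methyl and methoxy therefore cannot be told apart at this carbon. No available measurement offers an explanation for this result.

From the compounds shown here alone, whether an amine or a carboxylic acid here would move the number beyond the scatter remains open. So does the effect of a methoxy placed elsewhere on the shared core.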